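Series notes: tert-butyl in place of pentyl

This account rests on a few compounds, and the source may have more. Where it says the series, first, only, none or still open, it means among the compounds named here.

Compound 2 `CCCCCC(C#CC(=O)OC)O/C=C/C(=O)OC` gives 1700 nM in a functional assay on SW1573 cells (Homo sapiens) for antiproliferative activity, read by sulforhodamine B assay, with a stated time of 48 h; a higher number here means a weaker inhibitor of growth, a lower number a stronger inhibitor of growth. Compound 3 `CCCCCCCCCCC(C#CC(=O)OC)O/C=C/C(=O)OC` gives 2000 nM and compound 1 `COC(=O)C#CC(C[C@@H](C)CCC=C(C)C)O/C=C/C(=O)OC` gives 2200 nM. Compound 2 holds the lowest of the three numbers; its nearest neighbour is compound 3 and its furthest is compound 1, and both gaps lie within the scatter, so no order among them can be read. Compound 4 `COC(=O)C#CC(O/C=C/C(=O)OC)C(C)(C)C` is not yet measured. Going by the values given here, the change tert-butyl in place of pentyl on a saturated chain carbon bound to an oxygen on an unsaturated carbon and a triple-bonded carbon is of the same kind as the one measured step. That step, a 1.2-fold higher number from compound 2 to compound 3 (0.07 log units; within the scatter), did not move the number beyond the scatter, so no shift beyond the scatter in this assay is expected, and the expected step is a 1.1-fold higher number from compound 2 to compound 4 (0.02 log units; within the scatter). Compound 4 is therefore expected to give 1800 nM, in the range 900 nM to 3600 nM.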

Compound 4, concentration for 50% growth inhibition: 3000 nM
Compound 4: middle estimate off by 1.7-fold (0.22 log units), on the low side; measured number inside the range.
By their numbers in this assay, from the lowest: compounds 2, 3, 1 and 4 (each within the scatter of the next).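

In this assay tert-butyl in place of pentyl gives a 1.8-fold higher number from compound 2 to compound 4 (0.25 log units; within the scatter) and so adds a second kind of change at this position to the chain lengthening already seen. On a saturated chain carbon bound to an oxygen on an unsaturated carbon and a triple-bonded carbon, a group of 4 carbons in tert-butyl form therefore cannot be told apart from pentyl in this series.

Going by these compounds, whether an amine, a carboxylic acid or a phenyl ring at this position would move the number beyond the scatter stays open. No measurement here offers an explanation for the result.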